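This account rests on a few compounds, and the source may have more. Where it says the series, first, only, none or still open, it means among the compounds named here.

Compound 1, `Cc1cc(Nc2cc(-c3ccccc3)[nH]n2)n2nc(SCc3csc4ccccc34)nc2n1`: 29200 nM
Compound 2, `Cc1cc(Nc2cc(-c3ccc(F)cc3)[nH]n2)n2nc(SCc3ccc(Br)cc3)nc2n1`: 34200 nM

In an ADME assay on GES1 cells (Homo sapiens) for inhibition, read by MTT assay, with a stated time of 72 h (a lower number here means a stronger inhibitor, a higher number a weaker inhibitor), compound 1 gives 29200 nM, the lower of the two numbers recorded; compound 2 gives 34200 nM, a gap that lies within the scatter, so the two are not told apart. Compound 3, `Cc1cc(Nc2cc(-c3ccccc3)[nH]n2)n2nc(SCC3CC3)nc2n1`, is not yet measured. It differs from compound 1 by cyclopropyl in place of 1-benzothiophen-3-yl on a saturated chain carbon bound to a sulfur. Within the data shown here, with no measured step of this kind to lean on, the expected step from compound 1 to compound 3 in this assay is a 1.5-fold higher number from compound 1 to compound 3 (0.19 log units; within the scatter), a modest move toward a weaker inhibitor that may not exceed the scatter. Compound 3 is thus estimated at 45000 nM, in the range 20000 nM to 100000 nM.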

Compound 3, half-maximal inhibitory concentration: > 50000 nM
Compound 3: no number, only a limit (the forecaster's own chance of this, stated with the estimate: 30%); middle value at least 1.1-fold (0.04 log units) from the limit.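

In this assay, cyclopropyl in place of 1-benzothiophen-3-yl on a saturated chain carbon bound to a sulfur gives an at least 1.7-fold higher number from compound 1 to compound 3 (0.23 log units; that floor lies within the scatter), the first single-place step read at this position. Compound 3 carries only a limit, not a number, so the step has a floor and no upper end: the limit of > 50000 nM in this assay, at which 1 of the 3 values shown sits. This change brings no move toward a stronger inhibitor, though its floor alone does not set the two compounds apart. Going by these compounds, whether the full step exceeds the scatter stays open. So does how an amine, a carboxylic acid or a longer chain would read at this place in this assay.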